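A few compounds are considered here, and "the series" means these few. Any claim that something is new, unique, unknown or untested is made for them only; others in the source may bear on it.

Measured compounds:
- compound 1 `COc1ccc2c(c1)NC(=O)CN2c1nc(NCCCO)nc2ccccc12`: 4.92 nM
- compound 2 `COc1ccc2c(c1)NC(=O)CN2c1nc(NC2CC2)nc2ccccc12`: 2.11 nM
- compound 3 `CCCCNc1nc(N2CC(=O)Nc3cc(OC)ccc32)c2ccccc2n1`: 5.25 nM

All three were tested in a functional assay on KB cells (Homo sapiens) for inhibition, read by sulforhodamine B assay, with a stated time of 48 h; a lower number here means a stronger inhibitor of growth, a higher number a weaker inhibitor of growth. Compound 1 stands second highest of the three numbers; compound 3 sits within the scatter of it, a 1.1-fold higher number from compound 1 to compound 3 (0.03 log units; within the scatter), while compound 2 sits beyond it, a 2.3-fold lower number from compound 1 to compound 2 (0.37 log units; beyond the scatter). Among the compounds with values here, the change from compound 2 to compound 3 is the only other step beyond the scatter, a 2.5-fold higher number from compound 2 to compound 3 (0.40 log units; beyond the scatter).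

Compound 4 `CCOc1nc(N2CC(=O)Nc3cc(OC)ccc32)c2ccccc2n1` differs from compound 1 as follows: ethoxy in place of (3-hydroxypropyl)amino on an aromatic carbon. Within the data shown here, none of the measured steps bears directly on this change. The steps measured so far swap one substituent for another on the same nitrogen, keeping a hydrogen-bond donor there in every case; compound 4 removes that donor altogether and shortens the group. From the compounds shown here alone, the three measured values span a narrow window, so the shared core appears to tolerate variation at this position, but the loss of the donor is untested. A modest weakening is expected, with wide uncertainty: the step is estimated as a 1.8-fold higher number from compound 1 to compound 4 (0.26 log units; within the scatter). For compound 4 the expected value in this assay is 9 nM, within a range of 2.5 nM to 35 nM.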

Compound 4, concentration for 50% growth inhibition: 11.6 nM
The estimate for compound 4 lay 1.3-fold (0.11 log units) below the measured number, and the stated range covers the measured number.
By their numbers in this assay, from the lowest: compound 2; then compounds 1 and 3 (each within the scatter of the next); then compound 4.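

In this assay, the substituent on the aromatic carbon between two ring nitrogen atoms now shows a measurable dependence on the linking atom and chain, which the three amino-linked compounds alone did not reveal. Ethoxy gives a higher number than each amine it replaces: (3-hydroxypropyl)amino (a 2.4-fold higher number from compound 1 to compound 4 (0.37 log units; beyond the scatter)), butylamino (a 2.2-fold higher number from compound 3 to compound 4 (0.34 log units; beyond the scatter)) and cyclopropylamino (a 5.5-fold higher number from compound 2 to compound 4 (0.74 log units; beyond the scatter)), so compound 4 is the weakest inhibitor of growth of the four, though each step remains modest and the value stays in the same low range as the others. No supporting measurement is available to explain this result.

The change from amino substituent to ethoxy alters the linking atom, the hydrogen-bond donor count and the chain together, so these compounds cannot separate the contribution of each. Butoxy would compare directly with compound 3 at matched chain length, while dimethylamino would keep a nitrogen at this carbon without its hydrogen, and the two together would help show which part of the change accounts for the higher number.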